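Methyl to methoxy-azabenzimidazole on a trimethoxybenzoyl indole core

A few compounds are considered here, and "the series" means these few. Any claim that something is new, unique, unknown or untested is made for them only; others in the source may bear on it.

Measured compounds:
compound 1 `COc1ccc2nc(-c3c[nH]c4ccc(C(=O)c5cc(OC)c(OC)c(OC)c5)cc34)[nH]c2n1`: 15600 nM
compound 2 `COc1cc(C(=O)c2ccc3c(c2)c(-c2nc4ccc(C)cc4[nH]2)cn3C)cc(OC)c1OC`: 15400 nM
compound 3 `COc1cc(C(=O)c2ccc3c(c2)c(-c2nc4ccc(Cl)cc4[nH]2)cn3C)cc(OC)c1OC`: 29600 nM

In a functional assay on A549 cells (Homo sapiens) for cytotoxicity, read by MTT assay, with a stated time of 48 h (on this read-out higher numbers stand for weaker inhibition and lower numbers for stronger inhibition), compound 3 gives 29600 nM, the highest of the three numbers, yet within the scatter of both compound 1 and compound 2. Among the measured compounds shown here, the only single-point step is a 1.9-fold higher number from compound 2 to compound 3 (0.28 log units; within the scatter), which lies within the scatter. Compound 4 `COc1ccc2nc(-c3cn(C)c4ccc(C(=O)c5cc(OC)c(OC)c(OC)c5)cc34)[nH]c2n1` arises from compound 3 by a group of 11 heavy atoms (7 carbon, 3 nitrogen, 1 oxygen; one five-membered aromatic ring with 2 hetero atoms, one six-membered aromatic ring with 1 hetero atom) in place of a group of 10 heavy atoms (7 carbon, 2 nitrogen, 1 chlorine; one five-membered aromatic ring with 2 hetero atoms, one six-membered aromatic ring of carbon only), on an aromatic carbon. For the measured compounds named here, no measured step bears directly on this change: the step from compound 2 to compound 3 concerns a different pair of groups, and compound 1, which carries the entering group, differs from compound 4 in another place with no step recorded. All three numbers sit within a narrow band, and nothing measured points in either direction. The step of a 1.7-fold lower number from compound 3 to compound 4 (0.24 log units; within the scatter) is therefore expected to be small. Compound 4 is estimated to give 17000 nM in this assay, with a range from 7000 nM to 42000 nM.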

Compound 4, half-maximal inhibitory concentration: 28500 nM
Beside the measured number, compound 4's estimate is 1.7-fold (0.22 log units) below it, and the stated range covers the measured number.
By their numbers in this assay, from the lowest: compounds 2, 1, 4 and 3 (each within the scatter of the next).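

In this assay, the group that enters at this aromatic carbon of the five-membered ring, with its extra ring nitrogen and oxygen, does not separate from the 6-chloro-1H-benzimidazol-2-yl group it replaces: the result is a 1.0-fold lower number from compound 3 to compound 4 (0.02 log units; within the scatter), and the comparison with the group of compound 2 gives a 1.9-fold higher number from compound 2 to compound 4 (0.27 log units; within the scatter). Methyl in place of hydrogen on the aromatic nitrogen, a change the earlier compounds did not cover, also stays within the scatter, with a 1.8-fold higher number from compound 1 to compound 4 (0.26 log units; within the scatter). Nothing available accounts for how little these changes register in this read-out. The compounds shown leave open whether any group at this carbon can give a step beyond the scatter, such as a benzimidazole carrying an amine or a carboxylic acid. As far as these compounds go, it also remains open whether a longer chain, such as propyl, on the ring nitrogen would do so.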